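The source may report more compounds than this note shows. Statements on the series, on what has been measured and on what is new or still open speak of the compounds shown alone.

In a functional assay on HepG2 cells (Homo sapiens) for inhibition, read by MTT assay, with a stated time of 48 h (a higher number here means a weaker inhibitor, a lower number a stronger inhibitor), compound 1 `COc1ccc(N(C)c2nc(C)nc3ccccc23)cc1C(=O)OCC[Se]C#N` gives 890 nM, compound 2 `COc1ccc(N(C)c2nc(C)nc3ccccc23)cc1C(=O)OCCCC[Se]C#N` gives 975 nM and compound 3 `COc1ccc(N(C)c2nc(C)nc3ccccc23)cc1C[Se]C#N` gives 1110 nM, so compound 3 cannot be told apart from the other two. Compound 4 `COc1ccc(N(C)c2nc(C)nc3ccccc23)cc1OCCN` differs from compound 3 as follows: a group of 4 heavy atoms (2 carbon, 1 nitrogen, 1 oxygen; no ring) in place of a group of 4 heavy atoms (2 carbon, 1 nitrogen, 1 selenium; no ring), on an aromatic carbon. The entering 2-aminoethoxy sits ortho to a methoxy group. The measured steps, a 1.1-fold higher number from compound 1 to compound 2 (0.04 log units; within the scatter), a 1.2-fold higher number from compound 1 to compound 3 (0.10 log units; within the scatter) and a 1.1-fold higher number from compound 2 to compound 3 (0.06 log units; within the scatter), are all small, but each compound in them keeps its selenium and nitrile, so none tests their loss. With no measured shift to build on, the expected step is a 1.1-fold lower number from compound 3 to compound 4 (0.05 log units; within the scatter), with no direction expected beyond the scatter, though this is uncertain. For compound 4 the estimate is 1000 nM, with an expected range of 250 nM to 5000 nM.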

Compound 4, half-maximal inhibitory concentration: 343 nM
For compound 4 the middle estimate is 2.9-fold (0.46 log units) above the measured one; the range from low to high includes it.
By their numbers in this assay, from the lowest: compound 4; then compounds 1, 2 and 3 (each within the scatter of the next).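

In this assay, among these compounds, 2-aminoethoxy is the only group on this aromatic carbon that gives a step beyond the scatter, with a 3.2-fold lower number from compound 3 to compound 4 (0.51 log units; beyond the scatter) and a 2.8-fold lower number from compound 2 to compound 4 (0.45 log units; beyond the scatter) and a 2.6-fold lower number from compound 1 to compound 4 (0.41 log units; beyond the scatter) all pointing the same way. The position therefore responds to a change of group, although the three selenium-bearing groups could not be told apart. No measurement shown accounts for this step.

Going by these compounds, whether the amine or the ether oxygen carries the step stays open. So does how a 2-hydroxyethoxy group or a longer chain ending in an amine would read here.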